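This account rests on a few compounds, and the source may have more. Where it says the series, first, only, none or still open, it means among the compounds named here.

Two compounds of a shared core were tested in a functional assay on HUVEC cells (Homo sapiens) for antiproliferative activity, read by sulforhodamine B assay, with a stated time of 48 h; a higher number here means a weaker inhibitor, a lower number a stronger inhibitor. Compound 1 `COc1cc2c(Nc3ccc(NC(=O)Nc4cccc(F)c4)c(F)c3)ncnc2cc1OCC1CCN(C)CC1` gives 185 nM. Compound 2 `CN1CCC(COc2ccc3c(Nc4ccc(NC(=O)Nc5ccc(Cl)c(C(F)(F)F)c5)cc4)ncnc3c2)CC1` gives 92 nM, and this pair of numbers lies within the scatter of repeated measurements, so neither compound can be set apart from the other on this evidence. Compound 3 `CN1CCC(COc2ccc3c(Nc4ccc(NC(=O)NC5CC5)cc4)ncnc3c2)CC1` has not yet been measured; it differs from compound 2 in one place: cyclopropyl in place of 4-chloro-3-(trifluoromethyl)phenyl on an amide-type nitrogen. Among the compounds with values here, no measured pair shows a change of this kind, so the expectation rests on the structural change alone. For compound 3 the step of an 8.7-fold higher number from compound 2 to compound 3 (0.94 log units; beyond the scatter) is expected to go beyond the scatter, toward a weaker inhibitor. Compound 3 is estimated at 800 nM, within a range from 250 nM to 3000 nM.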

Compound 3, half-maximal inhibitory concentration: 324 nM
Estimate against measurement, compound 3: 2.5-fold (0.39 log units) above; low and high end bracket the measured number.
By their numbers in this assay, from the lowest: compounds 2, 1 and 3 (each within the scatter of the next, the first and the last beyond it).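

In this assay, cyclopropyl in place of 4-chloro-3-(trifluoromethyl)phenyl on an amide-type nitrogen gives a 3.5-fold higher number from compound 2 to compound 3 (0.55 log units; beyond the scatter) and so makes a modest but readable difference. Within the data shown here, this is the first step at this position, and it shows that the aromatic ring and its chlorine and trifluoromethyl groups can all leave with the compound still active at a level that can be measured. No measurement shown accounts for the size of this step.

As far as these compounds go, it remains open whether an unsubstituted phenyl or a cyclohexyl on the same nitrogen would give a number closer to that of compound 2 or of compound 3. The two groups exchanged here also leave unseparated the roles of the ring and of its chlorine and trifluoromethyl groups.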